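Replacing 2,4-difluorophenyl with pyridin-2-yl: what to expect

The compounds below may be only part of what the source reports. "The series", "measured", "known", "first", "only" and "open" are said of these compounds alone.

Of the compounds shown here, three built on one shared core have been measured in a functional assay on MIA PaCa-2 cells (Homo sapiens) for cytotoxicity, read by MTT assay, with a stated time of 72 h; a higher number here means a weaker inhibitor, a lower number a stronger inhibitor. Compound 1 `COC1=CC(=O)c2c(COc3ccc(N)cc3)c(C)n(C)c2C1=O` gives 160 nM. Compound 2 `COC1=CC(=O)c2c(COc3ccc(F)cc3)c(C)n(C)c2C1=O` gives 493 nM. Compound 3 `COC1=CC(=O)c2c(COc3ccc(F)cc3F)c(C)n(C)c2C1=O` gives 75 nM, the lowest number of the three, and its gaps to both others lie beyond the scatter.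

Compound 4 `COC1=CC(=O)c2c(COc3ccccn3)c(C)n(C)c2C1=O` has not yet been measured. It carries pyridin-2-yl in place of 2,4-difluorophenyl on an oxygen on a saturated carbon.

Among the measured compounds shown here, no measured compound carries pyridin-2-yl, so the evidence is indirect. The closest guide is the step of a 6.6-fold lower number from compound 2 to compound 3 (0.82 log units; beyond the scatter), where fluoro takes the place of hydrogen on an aromatic carbon. The step of a 2.1-fold lower number from compound 1 to compound 3 (0.33 log units; beyond the scatter) shows a smaller change when 2,4-difluorophenyl takes the place of 4-aminophenyl, and the step of a 3.1-fold higher number from compound 1 to compound 2 (0.49 log units; beyond the scatter) shows that a single fluoro did not match the amino compound. Compound 4 has no fluoro at all, so a modest step towards a higher number in this assay is expected, of about the size separating compound 3 from compound 2. The expected step is a 4.7-fold higher number from compound 3 to compound 4 (0.67 log units; beyond the scatter). For compound 4 the estimated value is 350 nM, with an expected range from 120 nM to 1000 nM.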

Compound 4, half-maximal inhibitory concentration: 2390 nM
For compound 4 the middle estimate is 6.8-fold (0.83 log units) below the measured one; the measured number lies above the stated range.
By their numbers in this assay, from the lowest: compound 3; then compound 1; then compound 2; then compound 4.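

In this assay, the change to pyridin-2-yl gives a 32-fold higher number from compound 3 to compound 4 (1.50 log units; beyond the scatter), so at this position on the oxygen, swapping a ring of carbon only for a ring with a hetero atom can cost far more than any difference among the three earlier rings. The lack of fluoro alone does not account for the result: compound 1 also has no fluoro, yet the record shows a 15-fold higher number from compound 1 to compound 4 (1.17 log units; beyond the scatter), and even the least favourable of the earlier rings, 4-fluorophenyl, gives way with a 4.8-fold higher number from compound 2 to compound 4 (0.69 log units; beyond the scatter), leaving compound 4 with the highest number of the four. No measurement shown here explains why this ring falls so far behind the others.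

With only one ring containing a hetero atom, the compounds shown leave open whether the loss belongs to pyridine rings in general or to pyridin-2-yl in particular, a question that pyridin-3-yl and pyridin-4-yl would address. They also leave open whether fluoro on the pyridine ring would recover what was lost, as it did on the ring of carbon only in going from compound 2 to compound 3.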